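Bromo on the Phenyl Ring: From Compound 3 to Compound 4

A few compounds are considered here, and "the series" means these few. Any claim that something is new, unique, unknown or untested is made for them only; others in the source may bear on it.

Compound 3 `COc1cc2c(Oc3ccc(NC(=O)c4nn(-c5ccccc5)c(=O)c5ccccc45)cc3F)ccnc2cc1OCCCN1CCCCC1` was tested in a functional assay on MKN-45 cells (Homo sapiens) for cytotoxicity, read by MTT assay, with a stated time of 72 h (on this read-out lower numbers stand for stronger inhibition and higher numbers for weaker inhibition), where compound 3 gives 590 nM. Among the three measured compounds it holds the second highest number, but the gaps are small. Compound 1 `COc1cc2c(Oc3ccc(NC(=O)c4nn(-c5ccccc5)c(=O)c5ccccc45)cc3F)ccnc2cc1OCCCN1CCCC1` gives 530 nM in this assay, and the step of a 1.1-fold higher number from compound 1 to compound 3 (0.05 log units; within the scatter). Compound 2 `COc1cc2c(Oc3ccc(NC(=O)c4nn(-c5ccccc5)c(=O)c5ccccc45)cc3F)ccnc2cc1OCCCN1CCN(C)CC1` gives 620 nM, and the step of a 1.1-fold lower number from compound 2 to compound 3 (0.02 log units; within the scatter). Between the other two, a 1.2-fold higher number from compound 1 to compound 2 (0.07 log units; within the scatter). All three steps lie within the scatter, so the three compounds cannot be ordered against one another.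

Compound 4 `COc1cc2c(Oc3ccc(NC(=O)c4nn(-c5ccc(Br)cc5)c(=O)c5ccccc45)cc3F)ccnc2cc1OCCCN1CCCCC1` arises from compound 3 by bromo in place of hydrogen on an aromatic carbon, which read one bond further out is phenyl to 4-bromophenyl, the bromo entering on a six-membered aromatic ring of carbon only, para to a large group. Among the compounds with values here, none of the measured steps touches this ring; each of them exchanges the amine at the end of the chain, and each stayed within the scatter. The measured steps therefore give no guide to this change. The shared core is unchanged and the three measured numbers cluster closely, so the step of a 1.2-fold lower number from compound 3 to compound 4 (0.07 log units; within the scatter) is expected to stay within the scatter. Compound 4 is estimated at 500 nM, with a range from 200 nM to 1500 nM.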

Compound 4, half-maximal inhibitory concentration: 500 nM
The estimate for compound 4 equals the measured number at the digits printed; the range from low to high includes it.
By their numbers in this assay, from the lowest: compounds 4, 1, 3 and 2 (each within the scatter of the next).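

Compound 4 is the only compound shown that is changed on the phenyl ring rather than at the amine on the end of the chain, so it gives the one reading of this position. In this assay, bromo in place of hydrogen, on an aromatic carbon para to a large group, gives a 1.2-fold lower number from compound 3 to compound 4 (0.07 log units; within the scatter), so this single heavy atom leaves the number indistinguishable from that of compound 3. The phenyl to 4-bromophenyl change therefore joins the amine exchanges among the steps that stay within the scatter, which shows that this position can carry bromo with no measurable change in this cytotoxicity read-out, and nothing given here explains that outcome.

One substituent at one place cannot show whether this position is generally insensitive, and a methoxy group, a carboxylic acid or a primary amine in place of the bromo could still shift the number beyond the scatter. From the compounds shown here alone, it also remains open whether 4-bromophenyl would behave the same way with pyrrolidin-1-yl or 4-methylpiperazin-1-yl at the end of the chain.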